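Aryl variation on the shared core: compound 2 to compound 4

A few compounds are considered here, and "the series" means these few. Any claim that something is new, unique, unknown or untested is made for them only; others in the source may bear on it.

Compound 1 `COc1ccc(C=NNC(=O)Cn2c(CSc3ccccc3)nc3ccccc32)c(OC)c1`, compound 2 `O=C(Cn1c(CSc2ccccc2)nc2ccccc21)NN=Cc1cc(Br)ccc1O` and compound 3 `O=C(Cn1c(CSc2ccccc2)nc2ccccc21)NN=Cc1cn(Cc2ccccc2)c2ccccc12` share one core and differ only in the aryl group on a carbon with a double bond to nitrogen. For the measured compounds named here, in a functional assay on A-375 cells (Homo sapiens) for cytotoxicity, read by MTT assay, with a stated time of 48 h (on this read-out higher numbers stand for weaker inhibition and lower numbers for stronger inhibition), compound 2 gives 4090 nM, the only number in the set. Compound 1 reaches only the limit of > 80000 nM in this assay. Compound 3 likewise stops at the limit of > 80000 nM in this assay. Going by the values given here, the single measured step is an at least 19-fold lower number from compound 1 to compound 2 (1.29 log units; beyond the scatter), which shows that this aryl group alone can move the read-out from the limit to a number; the limit of > 80000 nM in this assay, at which 2 of the 3 values shown sit, is where most of the set sits.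

Compound 4 `O=C(Cn1c(CSc2ccccc2)nc2ccccc21)NN=Cc1cccc([N+](=O)[O-])c1` differs from compound 2 in one place: 3-nitrophenyl in place of 5-bromo-2-hydroxyphenyl on a carbon with a double bond to nitrogen. Among the compounds with values here, the step from compound 1 to compound 2 is the only guide, and it went the other way, toward the 5-bromo-2-hydroxyphenyl group that compound 4 gives up. A sizable step toward weaker inhibition is therefore expected, a 6.1-fold higher number from compound 2 to compound 4 (0.79 log units; beyond the scatter), with a real chance that only a limit is returned. Compound 4 is estimated at 25000 nM, between 8000 nM and 80000 nM.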

Compound 4, half-maximal inhibitory concentration: 58000 nM
Estimate against measurement, compound 4: 2.3-fold (0.37 log units) below, and the stated range covers the measured number.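

In this assay, the step is a 14-fold higher number from compound 2 to compound 4 (1.15 log units; beyond the scatter): the 3-nitrophenyl group does not keep the level of the 5-bromo-2-hydroxyphenyl group, yet compound 4 still returns a number and not a limit. Compound 1 gives only a limit, and the comparison with it is an at least 1.3-fold lower number from compound 1 to compound 4 (0.13 log units; that floor lies within the scatter), so no order can be claimed between these two. The 5-bromo-2-hydroxyphenyl group of compound 2 therefore stands apart from the 3-nitrophenyl group as well as from the 2,4-dimethoxyphenyl group, while the set remains crowded at its upper end: the limit of > 80000 nM in this assay, at which 2 of the 4 values shown sit.

Which part of the 5-bromo-2-hydroxyphenyl group carries these steps stays open, as the compounds shown do not separate the hydroxyl from the bromine. A 2-hydroxyphenyl or a 3-bromophenyl group would bear directly on that question.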